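This account rests on a few compounds, and the source may have more. Where it says the series, first, only, none or still open, it means among the compounds named here.

Compound 2 `CSc1nnc(COc2ccccc2C2=NOC(c3ccc(Cl)cc3Cl)C2)n1NC(=O)c1ccccc1` and compound 1 `C=CCSc1nnc(COc2ccccc2C2=NOC(c3ccc(Cl)cc3Cl)C2)n1NC(C)=O` share one core, and the two are told apart by what sits on the amide nitrogen and on the sulfur. Among the measured compounds shown here, in an ADME assay (MDM cells, Homo sapiens) for cytotoxicity, read by resazurin assay, with a stated time of 3 days (on this read-out lower numbers stand for stronger inhibition and higher numbers for weaker inhibition), compound 2 gives 2.2 ug/mL, the only number this set shows. For compound 1 the outcome in this assay stands as "not determined" (no result reported). For the measured compounds named here, no step between measured compounds can be drawn from this, so compound 2 stands alone as the single reference point. Compound 3 `CSc1nnc(COc2ccccc2C2=NOC(c3ccc(Cl)cc3Cl)C2)n1NC(C)=O` is the next compound, and it differs from compound 2 by methyl in place of phenyl on a carbonyl carbon. Going by the values given here, with no comparable pair to lean on, the expected move in this assay is a modest weakening of the cytotoxic reading, estimated as a 2.3-fold higher number from compound 2 to compound 3 (0.36 log units; beyond the scatter), with a real chance of no change beyond the scatter. Compound 3 is therefore expected to give 5 ug/mL, between 1.5 ug/mL and 20 ug/mL.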

Compound 3, half-maximal inhibitory concentration: 2.7 ug/mL
The estimate for compound 3 lay 1.9-fold (0.27 log units) above the measured number, and the stated range covers the measured number.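

In this assay, methyl in place of phenyl on a carbonyl carbon gives a 1.2-fold higher number from compound 2 to compound 3 (0.09 log units; within the scatter), the first comparison available at this position. Benzoyl and acetyl therefore read alike here, and the cytotoxic reading does not depend on the phenyl ring in this pair. Nothing at hand explains this result, and no measurement of any property of either group bears on it.

The compounds shown leave open whether a longer chain such as butyl, an amine or a carboxylic acid on that carbonyl carbon would also stay within the scatter of compound 2. They also leave open whether the same indifference would hold with another group on the sulfur, since this single pair carries methyl there in both compounds.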